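Swapping a pyridinyl for cyclopropyl on a urea

This account rests on a few compounds, and the source may have more. Where it says the series, first, only, none or still open, it means among the compounds named here.

Measured compounds:
compound 1, `CN1CCN(Cc2cc3nc(-c4ccc(NC(=O)Nc5cccnc5)cc4)nc(N4CC5CCC(C4)O5)c3s2)CC1`, 148 nM
compound 2, `CNC(=O)Nc1ccc(-c2nc(N3CC4CCC(C3)O4)c3sc(CN4CCN(S(C)(=O)=O)CC4)cc3n2)cc1`, 120 nM
compound 3, `CN1CCN(Cc2cc3nc(-c4ccc(NC(=O)Nc5ccncc5)cc4)nc(N4CC5CCC(C4)O5)c3s2)CC1`, 200 nM

In a functional assay on LNCaP cells (Homo sapiens) for cytotoxicity (a lower number here means a stronger inhibitor, a higher number a weaker inhibitor), compound 3 gives 200 nM. That number lies within the usual scatter of both compound 1 and compound 2, so the three measured compounds cannot be told apart on this read-out. Among the measured compounds shown here, the only step measured so far is a 1.4-fold higher number from compound 1 to compound 3 (0.13 log units; within the scatter), which moves the ring nitrogen of a pyridinyl group and leaves the number essentially where it was.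

Compound 4, `CN1CCN(Cc2cc3nc(-c4ccc(NC(=O)NC5CC5)cc4)nc(N4CC5CCC(C4)O5)c3s2)CC1`, differs from compound 3 in one place: cyclopropyl in place of pyridin-4-yl on an amide-type nitrogen. For the measured compounds named here, no measured step replaces an aromatic ring with a small saturated ring on this urea, so the measured step offers no direct guide; it only shows that modest edits at this end of the molecule have not shifted the number beyond the scatter. Compound 4 is therefore expected near compound 3, with a wider uncertainty toward a weaker result: the estimated step is a 1.3-fold higher number from compound 3 to compound 4 (0.10 log units; within the scatter), and the estimate for compound 4 in this assay is 250 nM, in the range from 90 nM to 700 nM.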

Compound 4, half-maximal inhibitory concentration: 400 nM
Compound 4: middle estimate off by 1.6-fold (0.20 log units), on the low side; measured number inside the range.
By their numbers in this assay, from the lowest: compounds 2, 1, 3 and 4 (each within the scatter of the next, the first and the last beyond it).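

Replacing the aromatic ring on this amide-type nitrogen with a small saturated ring can now be read from two starting compounds in this assay on the same urea. Cyclopropyl in place of pyridin-4-yl gives a 2.0-fold higher number from compound 3 to compound 4 (0.30 log units; within the scatter) and stays within the scatter, while cyclopropyl in place of pyridin-3-yl gives a 2.7-fold higher number from compound 1 to compound 4 (0.43 log units; beyond the scatter) and is the only step shown that passes the scatter, and only modestly. This position therefore responds to the change, but weakly, and the reading depends on which pyridinyl compound serves as the reference.

From the compounds shown here alone, whether the ring nitrogen of the pyridinyl group matters, or only the presence of an aromatic ring, stays open: a phenyl ring or a butyl chain on this nitrogen could separate the two. No measurement available here explains the step.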